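A hydroxy-to-carboxy swap on an anilide quinoline scaffold

A few compounds are considered here, and "the series" means these few. Any claim that something is new, unique, unknown or untested is made for them only; others in the source may bear on it.

Three anilides of a shared core were tested in a functional assay on A-375 cells (Homo sapiens) for antiproliferative activity, read by MTT assay, with a stated time of 24 h, tested at 100 ug/mL; a higher number here means a stronger effect of the compound at the concentration tested, a lower number a weaker effect. Compound 1 `COc1ccc2nc(C(=O)Nc3ccc(-c4ccccc4)cc3)c(C)c(O)c2c1` gives 66.9%. Compound 2 `Cc1c(C(=O)Nc2ccc(-c3ccccc3)cc2)nc2ccccc2c1O` gives 52.3%. Compound 3 `Cc1ccc2nc(C(=O)Nc3c(F)cc(-c4cccc(F)c4)cc3F)c(C)c(C(=O)O)c2c1` gives 37.3%. For the measured compounds named here, the one step between compounds that differ in a single place is a number 14.6 percentage points lower from compound 1 to compound 2 (beyond the scatter). Compound 2 therefore stands second of the three numbers, beyond the scatter below compound 1 and beyond the scatter above compound 3.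

The step from compound 2 to compound 4 `Cc1c(C(=O)Nc2ccc(-c3ccccc3)cc2)nc2ccccc2c1C(=O)O` is carboxy in place of hydroxy on an aromatic carbon. Going by the values given here, no measured pair differs only in this way; compound 3, which carries the carboxy group, also differs from compound 2 in several other places, so its value shows only that a carboxy-bearing member sits at the low end of these three numbers. Among the compounds with values here, with no direct step to rest on, a modest downward step is expected in this assay, a number 10.3 percentage points lower from compound 2 to compound 4 (beyond the scatter), with a wide range. Compound 4 is estimated at 42%, between 25% and 60%.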

Compound 4, a percentage reported as inhibition, at one concentration (the size of the read-out at that concentration, not a potency): 50.3%
Beside the measured number, compound 4's estimate is 8.3 percentage points below it, within the range that was stated.
By their numbers in this assay, from the lowest: compound 3; then compounds 4 and 2 (each within the scatter of the next); then compound 1.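

Measured in this assay the change of hydroxy to carboxy at the position opposite the ring nitrogen and ortho to a methyl group gives a number 2 percentage points lower from compound 2 to compound 4 (within the scatter) so this pair cannot be told apart. The position thus takes a carboxy group of 3 heavy atoms in place of a hydroxy group of 1 with no change beyond the scatter, and the carboxy group alone does not account for the value of compound 3 at 37.3% since compound 3 also differs elsewhere. Nothing available explains why the two groups read alike.

On these data alone, whether an amine or a methyl ester at this position would also read alike remains open. So does whether carboxy would behave the same way alongside the methoxy group of compound 1.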